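The source may hold more compounds than are shown below. What is called first, only, known or untested is meant among the compounds shown, and "the series" means these compounds.

Notes on the cytotoxicity series. Compound 1 `CN1CCN(CC(=O)NC2CC3(N4CCCC4)CC(c4ccccc4)C2C(c2ccccc2)C3)CC1` and compound 3 `CN1CCN(CCC(=O)NC2CC3(N4CCCC4)CC(c4ccccc4)C2C(c2ccccc2)C3)CC1` share one core; compound 2 `CN1CCN(CC(=O)N2CCC3(N4CCCC4)CC(c4ccccc4)C2C(c2ccccc2)C3)CC1` and compound 4 `CN1CCN(CCC(=O)N2CCC3(N4CCCC4)CC(c4ccccc4)C2C(c2ccccc2)C3)CC1` share a second. The difference between the two cores is not broken down here.

In an ADME assay on L6 cells (Rattus norvegicus) for cytotoxicity, read by resazurin assay, with a stated time of 72 h (on this read-out lower numbers stand for stronger inhibition and higher numbers for weaker inhibition), compound 1 gives 50200 nM, compound 3 gives 86700 nM, and compound 2 gives 69100 nM. All three numbers lie within the scatter of one another.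

Compound 1 to compound 3 carries the change (4-methylpiperazin-1-yl)methyl in place of 4-methylpiperazin-1-yl on a saturated chain carbon bound to a carbonyl carbon and gives a 1.7-fold higher number from compound 1 to compound 3 (0.24 log units; within the scatter). Compound 2 to compound 4 carries the same change ((4-methylpiperazin-1-yl)methyl in place of 4-methylpiperazin-1-yl on a saturated chain carbon bound to a carbonyl carbon), at the same place.

For the measured compounds named here, for compound 4 in this assay a step like a 1.4-fold higher number from compound 2 to compound 4 (0.14 log units; within the scatter) is expected, resting on the one earlier step of a 1.7-fold higher number from compound 1 to compound 3 (0.24 log units; within the scatter) and on compound 2 at 69100 nM. Compound 4 is therefore estimated at 95000 nM, within 45000 nM to 200000 nM.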

Compound 4, half-maximal inhibitory concentration: 75400 nM
Compound 4: middle estimate off by 1.3-fold (0.10 log units), on the high side; the range from low to high includes it.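

In this assay the change gives a 1.1-fold higher number from compound 2 to compound 4 (0.04 log units; within the scatter), which can be set beside the step on the other core: the same change on two cores in this assay, a 1.7-fold higher number (0.24 log units; within the scatter) from compound 1 to compound 3 and a 1.1-fold higher number (0.04 log units; within the scatter) from compound 2 to compound 4, 1.6-fold (0.20 log units) apart, within the scatter of two such steps. The two steps cannot be told apart, so within these two cores the change reads the same on both. This does not show that the change has a real effect on either core, as each step stays within the scatter, and two cores give no rule for any further core.

Still open, as far as these compounds go, is whether a chain longer than 2-(4-methylpiperazin-1-yl)ethyl would move the number in this assay beyond the scatter. The same question holds for a morpholine or a primary amine in place of the 4-methylpiperazine ring.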